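Bringing an Aromatic Five-Membered Ring Back at the Chain Carbon

The compounds below may be only part of what the source reports. "The series", "measured", "known", "first", "only" and "open" are said of these compounds alone.

Compound 2 `CC(C)C(c1ccc(-c2ccc3cccc(F)c3c2)[nH]c1=O)N1CCN/C1=N\C#N` stands lowest of the two numbers measured in an ADME assay on microsomes from liver (Mus musculus) for metabolic stability (a higher number here means that the compound lasts longer, a lower number that the compound disappears faster), giving 0.207 h, while compound 1 `CC(C)C(Nc1nnc[nH]1)c1ccc(-c2ccc3cccc(F)c3c2)[nH]c1=O` gives 2.42 h. Compound 3 `CC(C)C(c1cnc(N)s1)c1ccc(-c2ccc3cccc(F)c3c2)[nH]c1=O` differs from compound 2 in one place: a group of 6 heavy atoms (3 carbon, 2 nitrogen, 1 sulfur; one five-membered aromatic ring with 2 hetero atoms) in place of a group of 8 heavy atoms (4 carbon, 4 nitrogen; one five-membered non-aromatic ring with 2 hetero atoms), on a saturated chain carbon bound to an aromatic carbon and a saturated chain carbon. Among the compounds with values here, the single measured step bears directly on this: a 12-fold lower number from compound 1 to compound 2 (1.07 log units; beyond the scatter), where a five-membered aromatic ring with 3 hetero atoms gave way to the non-aromatic ring. Since compound 3 again carries a five-membered aromatic ring on that chain carbon, a rise beyond the scatter is expected, though not necessarily all the way back. Compound 3 is estimated at 1 h, ranging from 0.3 h to 2.5 h, an expected step of a 4.8-fold higher number from compound 2 to compound 3 (0.68 log units; beyond the scatter).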

Compound 3, half-life: 0.08 h
Estimate against measurement, compound 3: 13-fold (1.10 log units) above, and the stated range ends above it.
By their numbers in this assay, from the lowest: compound 3; then compound 2; then compound 1.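

In this assay, an aromatic five-membered ring on this saturated chain carbon does not by itself give a longer half-life: placing 2-amino-1,3-thiazol-5-yl there gives a 2.6-fold lower number from compound 2 to compound 3 (0.41 log units; beyond the scatter), and a 30-fold lower number from compound 1 to compound 3 (1.48 log units; beyond the scatter). Compound 3 thus goes against any simple rule that aromatic rings outlast non-aromatic ones here, and the particular ring and its attachment seem to matter. No available evidence explains this drop. Still open, from the compounds shown here alone, is what separates compound 1 from compound 3: the ring itself, or the nitrogen linking it to the chain carbon. A thiazole without its amine, or a triazole attached through carbon, could help to separate these possibilities.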